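Cytotoxicity of a Thymine Piperidine Series: Aryl Ether to Alkyl Ether

The compounds below may be only part of what the source reports. "The series", "measured", "known", "first", "only" and "open" are said of these compounds alone.

Compound 1 `Cc1cn(C2CCN(Cc3cccc(Oc4ccc(Cl)cc4)c3)CC2)c(=O)[nH]c1=O` carries a 4-chlorophenyl group on an oxygen on an aromatic ring. In an ADME assay on MRC5 cells (Homo sapiens) for cytotoxicity, read by fluorescence and resazurin assay, with a stated time of 3 days (a lower number here means a stronger inhibitor, a higher number a weaker inhibitor), compound 1 gives 25100 nM, a weak result that marks it as only a mild inhibitor of cell growth over the duration of the test. For the measured compounds named here, that number is the only one measured so far. Compound 2 `Cc1cn(C2CCN(Cc3cccc(Oc4ccncc4)c3)CC2)c(=O)[nH]c1=O`, which places a pyridinyl group on the same oxygen, has no result in this assay: its entry reads "not determined" (no result reported).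

Compound 3 `Cc1cn(C2CCN(Cc3cccc(OC4CCCCC4)c3)CC2)c(=O)[nH]c1=O` is the next step from compound 1. The change is cyclohexyl in place of 4-chlorophenyl on an oxygen on an aromatic ring. A flat, chlorine-bearing aromatic ring gives way to a saturated ring of the same size, with no donors or acceptors added or lost.

Nothing measured here shows how such a change moves cytotoxicity, so the expected step in this assay from compound 1 is small, in either direction, and probably within the scatter: a 1.2-fold higher number from compound 1 to compound 3 (0.08 log units; within the scatter). Compound 3 is therefore estimated to give 30000 nM, within a range from 12000 nM to 75000 nM.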

Compound 3, half-maximal inhibitory concentration: 23600 nM
Compound 3: the middle estimate sits 1.3-fold (0.10 log units) above what was measured, within the range that was stated.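

In this assay, cyclohexyl in place of 4-chlorophenyl on an oxygen on an aromatic ring gives a 1.1-fold lower number from compound 1 to compound 3 (0.03 log units; within the scatter) and so leaves the two compounds indistinguishable. For the compounds shown here, this is the first step measured at this position, and it shows that a six-membered aromatic ring bearing chlorine and a six-membered non-aromatic ring of carbon only can sit on this oxygen with no readable difference in this test of harm to cells. The change removes the chlorine and the aromatic ring in a single step, and no measured information here explains the result or separates those two parts of the change.

The pyridinyl group of compound 2 has no number, so a ring containing nitrogen on this oxygen remains unread, and a single step cannot show whether the position is generally insensitive to change. As far as these compounds go, it also remains open whether an amine, a carboxylic acid or a longer alkyl chain on this oxygen would leave the result just as unchanged, or whether any of them would move it beyond the scatter.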